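Swapping a thioamide-bearing para group for trifluoromethyl

This account rests on a few compounds, and the source may have more. Where it says the series, first, only, none or still open, it means among the compounds named here.

Measured compounds and their values in a functional assay on the whole organism for inhibition, with Rattus norvegicus as the target, at a dose of 30 mg/kg; on this read-out higher numbers stand for more inhibition at the one dose given (going by the name of the read-out) and lower numbers for less inhibition:
- compound 1, `C/N=C(\S)n1nc(-c2ccccc2)nc1N`: 54%
- compound 2, `C/N=C(\S)n1nc(-c2ccc(C#N)cc2)nc1N`: 87%
- compound 3, `C/N=C(\S)Nc1ccc(-c2nc(N)n(/C(S)=N/C)n2)cc1`: 31%

Compound 3 stands lowest of the three. Its nearest neighbour is compound 1, and the step of a number 23 percentage points lower from compound 1 to compound 3 (beyond the scatter) is beyond the scatter, while the step of a number 56 percentage points lower from compound 2 to compound 3 (beyond the scatter) is larger still.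

Compound 4 is `C/N=C(\S)n1nc(-c2ccc(C(F)(F)F)cc2)nc1N`. It differs from compound 3 in one place: a group of 4 heavy atoms (1 carbon, 3 fluorine; no ring) in place of a group of 5 heavy atoms (2 carbon, 2 nitrogen, 1 sulfur; no ring), on an aromatic carbon, sitting para to a large group on the carbon-only six-membered ring.

For the measured compounds named here, two measured steps bear on this change. The step of a number 33 percentage points higher from compound 1 to compound 2 (beyond the scatter) shows that a small group of few atoms at that position raised the number strongly. The step of a number 23 percentage points lower from compound 1 to compound 3 (beyond the scatter) shows that the larger five-atom group lowered it. Removing that larger group and putting in the four-atom trifluoromethyl is therefore expected to bring the number back up, and for compound 4 a step of a number 34 percentage points higher from compound 3 to compound 4 (beyond the scatter) in this assay is expected. Compound 4 is estimated at 65%, with a range from 40% to 90%.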

Compound 4, a percentage reported as inhibition, in the whole organism at one dose (the size of the read-out at that dose, not a potency): 91%
For compound 4 the middle estimate is 26 percentage points below the measured one; the measured number lies above the stated range.
By their numbers in this assay, from the lowest: compound 3; then compound 1; then compounds 2 and 4 (each within the scatter of the next).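

In this assay, trifluoromethyl in place of hydrogen gives a number 37 percentage points higher from compound 1 to compound 4 (beyond the scatter), so the rise seen with the nitrile is not confined to that one group. Trifluoromethyl in place of nitrile gives a number 4 percentage points higher from compound 2 to compound 4 (within the scatter), which leaves these two groups indistinguishable here, while replacing the larger sulfur-containing group of compound 3 gives a number 60 percentage points higher from compound 3 to compound 4 (beyond the scatter), so the low number of compound 3 is tied to that group rather than to the shared core. What lies behind these differences cannot be said from the data shown.

From the compounds shown here alone, it remains open whether an amine, a carboxylic acid or a simple methyl group at this place would keep the number high or lower it. Going by these compounds, with results at a single dose, how compound 2 and compound 4 would compare at other doses also remains open.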